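Moving the methyl group from compound 3 to compound 4

A few compounds are considered here, and "the series" means these few. Any claim that something is new, unique, unknown or untested is made for them only; others in the source may bear on it.

Measured compounds:
- compound 1, `Cc1ccc(CSc2n[nH]c(-n3[se]c4ccccc4c3=O)n2)cc1`: 34800 nM
- compound 2, `O=c1c2ccccc2[se]n1-c1nc(SCc2ccc(Cl)cc2)n[nH]1`: 40900 nM
- compound 3, `O=c1c2ccccc2[se]n1-c1nc(SCc2ccc(F)cc2)n[nH]1`: > 50000 nM

Three compounds share one core and differ only in the group on the benzyl arm. In a functional assay on HeLa cells (Homo sapiens) for antiproliferative activity, read by CCK-8 assay, with a stated time of 48 h (a higher number here means a weaker inhibitor, a lower number a stronger inhibitor), compound 1 gives 34800 nM. Compound 2 gives 40900 nM in this assay. For compound 3 the value > 50000 nM is a limit of this assay, not a number, as the evidence the limit of > 50000 nM in this assay, at which 1 of the 3 values shown sits, shows. All three are weak inhibitors, and the steps between them are small: a 1.2-fold higher number from compound 1 to compound 2 (0.07 log units; within the scatter), an at least 1.4-fold higher number from compound 1 to compound 3 (0.15 log units; that floor lies within the scatter) and an at least 1.2-fold higher number from compound 2 to compound 3 (0.08 log units; that floor lies within the scatter).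

Compound 4, `Cc1ccccc1CSc1n[nH]c(-n2[se]c3ccccc3c2=O)n1`, is not yet measured in this assay. The change from compound 3 is 2-methylphenyl in place of 4-fluorophenyl on a saturated chain carbon bound to a sulfur. The measured steps replace one group on the benzyl arm by another and stay within the scatter, so no step beyond the scatter is expected here either. The closest measured comparison is compound 1, whose methyl group stands elsewhere on the ring and which gives 34800 nM. For compound 4 a value around 40000 nM is estimated, between 20000 nM and 80000 nM, and the expected step from compound 3 is an at least 1.2-fold lower number from compound 3 to compound 4 (0.09 log units; that floor lies within the scatter).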

Compound 4, half-maximal inhibitory concentration: 6130 nM
Estimate against measurement, compound 4: 6.5-fold (0.81 log units) above; the measured number lies below the stated range.
By their numbers in this assay, from the lowest: compound 4; then compounds 1 and 2 (each within the scatter of the next). At a limit, above all of these: compound 3.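

Compound 1 and compound 4 carry the same methyl group on the benzyl arm, so the place of that group on the ring turns out to matter in this assay (a 5.7-fold lower number from compound 1 to compound 4 (0.75 log units; beyond the scatter)). This contrasts with the earlier swaps among the groups of the 4-substituted compounds, which all stayed within the scatter, and the 2-methylphenyl arm also gives a lower number than the 4-chlorophenyl arm (a 6.7-fold lower number from compound 2 to compound 4 (0.82 log units; beyond the scatter)) and the 4-fluorophenyl arm (an at least 8.1-fold lower number from compound 3 to compound 4 (0.91 log units; beyond the scatter)). That last step is only a floor, because compound 3 has a limit of the assay and not a number: the limit of > 50000 nM in this assay, at which 1 of the 4 values shown sits.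

The compounds shown do not tell whether the gain belongs to the methyl group itself or to any small group at that place on the ring, which a 2-chlorophenyl or 2-methoxyphenyl arm would help to separate. From the compounds shown here alone, a 3-methylphenyl arm is also missing from this set, so it remains open how the number changes as the methyl group moves around the ring, and why compound 4 stands apart.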